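Amide-side aryl replacement in a dipeptidyl ketoamide series

A few compounds are considered here, and "the series" means these few. Any claim that something is new, unique, unknown or untested is made for them only; others in the source may bear on it.

Measured so far in an assay on isolated protein for inhibition of Calpain-1 catalytic subunit (Homo sapiens); on this read-out higher numbers stand for weaker inhibition and lower numbers for stronger inhibition:
- compound 1 `CCC(NC(=O)C(CC(C)C)NC(=O)OCc1ccccc1)C(=O)C(=O)NCCCCCO`: 500 nM
- compound 2 `CCC(NC(=O)C(CC(C)C)NC(=O)OCc1ccccc1)C(=O)C(=O)NCC1CCCCC1`: 680 nM
- compound 3 `CCC(NC(=O)C(CC(C)C)NC(=O)OCc1ccccc1)C(=O)C(=O)NCc1ccccc1`: 200 nM

Compound 2 holds the highest number of the three. The nearest of the other two lies within the scatter: a 1.4-fold higher number from compound 1 to compound 2 (0.13 log units; within the scatter). The furthest lies beyond it: a 3.4-fold lower number from compound 2 to compound 3 (0.53 log units; beyond the scatter).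

Compound 4 `CCC(NC(=O)C(CC(C)C)NC(=O)OCc1ccccc1)C(=O)C(=O)NCc1cc(OC)cc(OC)c1` is not yet measured. It differs from compound 2 in one place: 3,5-dimethoxyphenyl in place of cyclohexyl on a saturated chain carbon bound to an amide-type nitrogen.

Within the data shown here, two measured steps bear on this change, both ending in the plain phenyl of compound 3: a 3.4-fold lower number from compound 2 to compound 3 (0.53 log units; beyond the scatter) and a 2.5-fold lower number from compound 1 to compound 3 (0.40 log units; beyond the scatter). Both are modest and run toward lower numbers. Among the measured compounds shown here, no measured compound carries the two methoxy groups, so their own contribution is unknown; the data give no basis for a further shift in either direction beyond what the phenyl step already shows.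

A modest step toward lower numbers in this assay is therefore expected for compound 4, of about the size seen for the plain phenyl: a 2.7-fold lower number from compound 2 to compound 4 (0.43 log units; beyond the scatter) is the estimated step. Compound 4 is expected to give 250 nM in this assay, with a range from 80 nM to 800 nM.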

Compound 4, inhibition constant: 2300 nM
Beside the measured number, compound 4's estimate is 9.2-fold (0.96 log units) below it; measured number above the stated range.
By their numbers in this assay, from the lowest: compound 3; then compounds 1 and 2 (each within the scatter of the next); then compound 4.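

In this assay, the two methoxy groups undo the gain seen with the plain phenyl and go well past it (a 12-fold higher number from compound 3 to compound 4 (1.06 log units; beyond the scatter)), the largest step among these compounds. The 3,5-dimethoxyphenyl group also gives higher numbers than both non-aromatic groups (a 3.4-fold higher number from compound 2 to compound 4 (0.53 log units; beyond the scatter); a 4.6-fold higher number from compound 1 to compound 4 (0.66 log units; beyond the scatter)), so an aromatic ring at this place does not by itself bring lower numbers in this series: compound 3 gives the lowest number of the four and compound 4 the highest, although both carry an aromatic ring. Nothing on hand accounts for the effect of the two methoxy groups.

Open, on these data alone, is whether a single methoxy group on the phenyl ring already produces part of this rise, and whether other substituents on that ring, such as chloro, hydroxy or a carboxylic acid, move the number the same way. Also open, as far as these compounds go, is whether the plain phenyl keeps its advantage when a longer chain, as in 2-phenylethyl, links it to the amide nitrogen.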